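Bromo for Chloro on the Meta Position of Compound 1

The compounds below may be only part of what the source reports. "The series", "measured", "known", "first", "only" and "open" are said of these compounds alone.

Compound 1 `Cc1ccc(OCC(=O)NNC(=O)c2cc3ccccc3oc2=O)c(C(=O)c2cccc(Cl)c2)c1` is the weakest of three measured analogues: in a functional assay on DLA cells (Mus musculus) for cytotoxicity, read by MTT assay, with a stated time of 48 h (on this read-out higher numbers stand for weaker inhibition and lower numbers for stronger inhibition), compound 1 gives 65500 nM, the highest number of the set. Compound 3 `Cc1ccc(OCC(=O)NNC(=O)c2cc3ccccc3oc2=O)c(C(=O)c2ccccc2Cl)c1` gives 53800 nM, and the step of a 1.2-fold lower number from compound 1 to compound 3 (0.09 log units; within the scatter) is too small to rank the two. Compound 2 `Cc1ccc(OCC(=O)NNC(=O)c2cc3ccccc3oc2=O)c(C(=O)c2ccccc2Br)c1` gives 10000 nM, and the step of a 6.6-fold lower number from compound 1 to compound 2 (0.82 log units; beyond the scatter) is the only clear movement among the three. Compound 4 `Cc1ccc(OCC(=O)NNC(=O)c2cc3ccccc3oc2=O)c(C(=O)c2cccc(Br)c2)c1` has not yet been measured. It differs from compound 1 in one place: bromo in place of chloro on an aromatic carbon.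

Within the data shown here, two measured steps bear on this. The step of a 6.6-fold lower number from compound 1 to compound 2 (0.82 log units; beyond the scatter) combines a change of halogen with a change of position, so it is only indirect evidence. The step of a 5.4-fold higher number from compound 2 to compound 3 (0.73 log units; beyond the scatter) is the same halogen swap, on the 2-bromophenyl and 2-chlorophenyl pair, read in the opposite direction; reversed, it points to a lower number when bromo replaces chloro. Among the measured compounds shown here, no measured pair tests this swap on the 3-substituted ring itself, so the expectation is moderated. The step from compound 1 to compound 4 is therefore expected to be a 3.0-fold lower number from compound 1 to compound 4 (0.47 log units; beyond the scatter), toward stronger inhibition. Compound 4 is expected to give about 22000 nM, within a range of 8000 nM to 60000 nM.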

Compound 4, half-maximal inhibitory concentration: 68500 nM
Estimate against measurement, compound 4: 3.1-fold (0.49 log units) below; measured number above the stated range.
By their numbers in this assay, from the lowest: compound 2; then compounds 3, 1 and 4 (each within the scatter of the next).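

In this assay, the halogen swap on the 3-chlorophenyl group produces no readable movement, with a 1.0-fold higher number from compound 1 to compound 4 (0.02 log units; within the scatter), so bromo brings no gain at this position in this pair. Compound 4 also cannot be separated from the 2-chlorophenyl analogue, with a 1.3-fold higher number from compound 3 to compound 4 (0.10 log units; within the scatter), whereas the two bromo compounds do separate, with a 6.9-fold higher number from compound 2 to compound 4 (0.84 log units; beyond the scatter), and compound 2 remains the strongest of the four; among these compounds, bromo gives a low number only in the 2-bromophenyl group. The same swap therefore does not carry over from the 2-substituted to the 3-substituted phenyl group: the same change on two cores in this assay, a 5.4-fold higher number (0.73 log units; beyond the scatter) from compound 2 to compound 3 and a 1.0-fold lower number (0.02 log units; within the scatter) from compound 4 to compound 1, 5.6-fold (0.75 log units) apart, beyond the scatter of two such steps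

As far as these compounds go, the low number rests on compound 2 alone, so it remains open whether an iodo or a methoxy group in place of the bromo of compound 2 would keep it. The compounds shown also leave open whether an amine or a carboxylic acid in place of the halogen of the 3-bromophenyl group of compound 4 would move the number at all.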